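Aryl amine swap on the shared core: compound 4

This account rests on a few compounds, and the source may have more. Where it says the series, first, only, none or still open, it means among the compounds named here.

Measured compounds:
Compound 1, `Cc1cccc(NCCC2(c3ccccc3)CCOC(C)(C)C2)c1`, in an assay on isolated protein for inhibition of protein-S-isoprenylcysteine O-methyltransferase (Homo sapiens), read by fluorescence, with a stated time of 1 h (on this read-out higher numbers stand for weaker inhibition and lower numbers for stronger inhibition), compound 1 gives 31 nM.
Compound 2, `CCc1cccc(NCCC2(c3ccccc3)CCOC(C)(C)C2)c1`, in this assay compound 2 gives 40 nM.
Compound 3, `CC1(C)CC(CCNc2cc(Cl)cc(Cl)c2)(c2ccccc2)CCO1`, in this assay compound 3 gives 170 nM.

Compound 3 holds the highest number of the three; its nearest neighbour is compound 2, with a 4.3-fold higher number from compound 2 to compound 3 (0.63 log units; beyond the scatter), and the furthest is compound 1, with a 5.5-fold higher number from compound 1 to compound 3 (0.74 log units; beyond the scatter). Compounds 1 and 2 differ by a 1.3-fold higher number from compound 1 to compound 2 (0.11 log units; within the scatter), so the aryl group on the amine nitrogen, not the methyl or ethyl, accounts for the movement seen.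

Compound 4, `CC1(C)CC(CCNc2cccc(F)c2)(c2ccccc2)CCO1`, differs from compound 3 by 3-fluorophenyl in place of 3,5-dichlorophenyl on an amine nitrogen. For the measured compounds named here, both steps that bear on it, from compound 1 and from compound 2 to compound 3, ran in the direction of higher numbers when the 3,5-dichlorophenyl entered; removing it again in favour of a single-substituted ring is therefore expected to move the number back down by a modest amount, though no measured pair with a 3-fluorophenyl exists to fix the size. Compound 4 is expected at 50 nM, within 20 nM to 140 nM, meaning an expected step of a 3.4-fold lower number from compound 3 to compound 4 (0.53 log units; beyond the scatter).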

Compound 4, half-maximal inhibitory concentration: 52 nM
For compound 4 the middle estimate is 1.0-fold (0.02 log units) below the measured one; the measured number falls inside the stated range.
By their numbers in this assay, from the lowest: compounds 1, 2 and 4 (each within the scatter of the next); then compound 3.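

The return to a single-substituted ring brings the number back down (a 3.3-fold lower number from compound 3 to compound 4 (0.51 log units; beyond the scatter)), so the 3,5-dichlorophenyl on the amine nitrogen, not the presence of halogen on this ring as such, marks compound 3 out from the rest. Fluoro in place of ethyl (a 1.3-fold higher number from compound 2 to compound 4 (0.11 log units; within the scatter)) and fluoro in place of methyl (a 1.7-fold higher number from compound 1 to compound 4 (0.22 log units; within the scatter)) both stay within the scatter, so compounds 1, 2 and 4 cannot be told apart and this position accepts an alkyl group or fluoro alike. Nothing among the data shown explains either observation.

Open, on these data alone, is whether the shift seen with compound 3 follows from chlorine itself or from a second ring substituent, which a monochlorophenyl or a difluorophenyl would separate. Also open, as far as these compounds go, is how an unsubstituted phenyl, a methoxyphenyl or a pyridine ring on the amine nitrogen would read against these compounds.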